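Thiophen-2-yl gives way to piperidin-1-yl on a carbonyl carbon

The compounds below may be only part of what the source reports. "The series", "measured", "known", "first", "only" and "open" are said of these compounds alone.

In an ADME assay on HepG2 cells (Homo sapiens) for inhibition, read by resazurin assay, with a stated time of 48 h (on this read-out lower numbers stand for an effect already at smaller amounts and higher numbers for an effect only at larger amounts of compound), compound 1 (`O=C(Nc1ccc2sc(-c3cccc(F)c3)nc2c1)N1CCCCC1`) reads > 50 uM as a limit of the assay and not a number. Compound 2 (`O=C(Nc1ccc2sc(-c3ccccc3)nc2c1)c1cccs1`) likewise shows > 50 uM as a limit, so it has no measured number of its own. These two readings are the whole of the measured picture (the limit of > 50 uM in this assay, at which 2 of the 2 values shown sit) and neither offers a point from which to count a change. Compound 3 (`O=C(Nc1ccc2sc(-c3ccccc3)nc2c1)N1CCCCC1`) has piperidin-1-yl in place of thiophen-2-yl on a carbonyl carbon as its difference from compound 2. Among the compounds with values here, no step between measured compounds is available as a guide. With compound 2 at > 50 uM as a limit, no step beyond the usual scatter is expected in this assay in either direction. The expected step (a step that the limit leaves unreadable from compound 2 to compound 3) is therefore only a rough estimate. The estimate for compound 3 is 60 uM with an expected range of 35 uM to 100 uM and a reading that stops at the limit again is the likeliest outcome.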

Compound 3, concentration for 90% of the maximal effect: > 50 uM
Compound 3 was reported as a limit; the forecaster's own chance of this, stated with the estimate: 85%; the middle value is on the limit's open side.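

No step can be read from compound 2 to compound 3 or from compound 1 to compound 3, as each reading in this assay is a limit and not a number: the limit of > 50 uM in this assay, at which 3 of the 3 values shown sit.

The compounds shown leave open whether piperidin-1-yl in place of thiophen-2-yl, or hydrogen in place of fluoro, changes the effect at all.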